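A few compounds are considered here, and "the series" means these few. Any claim that something is new, unique, unknown or untested is made for them only; others in the source may bear on it.

Compound 1 `O=C(CSc1nnc(NC(=O)c2c(Cl)cccc2Cl)s1)Nc1ccc(Br)cn1` gives 18600 nM in a functional assay on A875 cells (Homo sapiens) for antiproliferative activity, read by MTT assay, with a stated time of 48 h; on this read-out higher numbers stand for weaker inhibition and lower numbers for stronger inhibition.
Compound 2 `COc1ccccc1C(=O)Nc1nnc(SCC(=O)Nc2ccc(C)cn2)s1` gives only a limit, > 80000 nM.
Compound 3 `COc1ccccc1C(=O)Nc1nnc(SCC(=O)Nc2ccc(Cl)cn2)s1` gives only a limit, > 80000 nM.

Going by the values given here, compound 1 holds the only number in this set, as the other two values are limits (the limit of > 80000 nM in this assay, at which 2 of the 3 values shown sit). Among the compounds with values here, the one step measured within the set, a step that the two limits leave unreadable from compound 2 to compound 3, cannot be read in size. Compound 4 `O=C(CSc1nnc(NC(=O)CCl)s1)Nc1ccc(Br)cn1` differs from compound 1 by chloromethyl in place of 2,6-dichlorophenyl on a carbonyl carbon. Within the data shown here, no measured step touches this change, and the two limits say nothing about it, so the expectation rests on compound 1 alone. Compound 4 is therefore expected to stay close to compound 1 in this assay. The expected step is a 1.1-fold higher number from compound 1 to compound 4 (0.03 log units; within the scatter). Compound 4 is estimated at 20000 nM, within a range from 5000 nM to 80000 nM.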

Compound 4, half-maximal inhibitory concentration: 13900 nM
Compound 4: the middle estimate sits 1.4-fold (0.16 log units) above what was measured; the measured number falls inside the stated range.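

In this assay, the change on the carbonyl carbon gives a 1.3-fold lower number from compound 1 to compound 4 (0.13 log units; within the scatter). Within this pair, then, the six-membered aromatic ring of 2,6-dichlorophenyl is not required to keep the number where it stands, since chloromethyl, with no ring, serves equally well at this place. Nothing shown bears on the cause of this result. Going by these compounds, it remains open whether an amine, a carboxylic acid or a longer chain on this carbonyl carbon would also leave the number unchanged. On these data alone, whether chloromethyl would behave the same way with another group in place of the bromine on the far ring also stays open.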